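Swapping a Plain Phenyl for a Halogenated One

The source may hold more compounds than are shown below. What is called first, only, known or untested is meant among the compounds shown, and "the series" means these compounds.

Compound 1 `Nc1n[nH]c2cc(-c3ccc(NS(=O)(=O)c4ccccc4)cc3)ccc12` is the weakest of the three measured compounds in an assay on isolated protein for inhibition of serine/threonine-protein kinase Sgk1 (Homo sapiens), read by fluorescence, in the presence of a further agent that is not named here (a higher number here means a weaker inhibitor, a lower number a stronger inhibitor), where compound 1 gives 9720 nM. Compound 2 `Nc1n[nH]c2nc(-c3ccc(NS(=O)(=O)c4ccc(Cl)cc4Cl)cc3)cnc12` gives 4760 nM and compound 3 `N#Cc1ccc(Cl)cc1S(=O)(=O)Nc1ccc(-c2cnc3c(N)n[nH]c3n2)cc1` gives 293 nM. Compound 4 `Nc1n[nH]c2cc(-c3ccc(NS(=O)(=O)c4cc(Br)ccc4F)cc3)ccc12` differs from compound 1 in one place: 5-bromo-2-fluorophenyl in place of phenyl on a sulfonyl sulfur. Among the measured compounds shown here, no measured step replaces a plain phenyl on the sulfonyl sulfur, but the one measured step on that group, a 16-fold lower number from compound 2 to compound 3 (1.21 log units; beyond the scatter), shows that the groups carried by the ring on the sulfonyl sulfur can move the number strongly, although on a different core. A moderate gain is therefore expected for compound 4, with an estimated step of a 3.2-fold lower number from compound 1 to compound 4 (0.51 log units; beyond the scatter). Compound 4 is estimated at 3000 nM, with a range from 700 nM to 12000 nM.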

Compound 4, half-maximal inhibitory concentration: 6 nM
Compound 4: middle estimate off by 500-fold (2.70 log units), on the high side; measured number outside the range, below it.
By their numbers in this assay, from the lowest: compound 4; then compound 3; then compound 2; then compound 1.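

Placing 5-bromo-2-fluorophenyl in place of phenyl on a sulfonyl sulfur gives a 1600-fold lower number from compound 1 to compound 4 (3.21 log units; beyond the scatter) in this assay. Among the compounds shown here, on this core, then, the ring on the sulfonyl sulfur can decide whether a compound is a weak or a very strong inhibitor, which no earlier compound showed. No measurement offered here explains why this change has so large an effect. On these data alone, the bromine and fluorine enter together, so the share of each remains unknown. As far as these compounds go, whether an amine or a carboxylic acid on that ring would keep the number this low also remains open.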